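Swapping one aryl group on a shared core

The compounds below may be only part of what the source reports. "The series", "measured", "known", "first", "only" and "open" are said of these compounds alone.

Compound 1 `COc1cc(Nc2ncnc3c(NC(=O)Nc4ccc(C(F)(F)F)cc4[N+](=O)[O-])cccc23)cc(OC)c1`: > 20000 nM
Compound 2 `COc1cc(Nc2ncnc3c(NC(=O)Nc4ccc(Cl)cc4Cl)cccc23)cc(OC)c1`: 3060 nM

Both results come from a functional assay on RT-112 cells (Homo sapiens) for antiproliferative activity, read by MTT assay, with a stated time of 72 h; a higher number here means a weaker inhibitor of growth, a lower number a stronger inhibitor of growth. For compound 1 the assay reports only a limit, > 20000 nM, and not a number. Among the measured compounds shown here, that leaves compound 2, at 3060 nM, as the only true number so far, with no second number to compare it against.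

The next compound, compound 3 `COc1cc(Nc2ncnc3c(NC(=O)Nc4ccc(C(F)(F)F)cc4)cccc23)cc(OC)c1`, keeps the shared core and changes one group: 4-(trifluoromethyl)phenyl in place of 2,4-dichlorophenyl on an amide-type nitrogen.

For the measured compounds named here, no measured pair of compounds shows how large such a change can be, so any forecast rests on very little. Compound 1 also carries a trifluoromethyl group, and its result is the limit > 20000 nM. This tilts the expectation in this assay towards a higher number than that of compound 2, meaning weaker growth inhibition, though perhaps by a step not far beyond the usual scatter. The expected step is a 1.8-fold higher number from compound 2 to compound 3 (0.25 log units; within the scatter). Compound 3 is estimated at 5500 nM, with an expected range from 1800 nM to 17000 nM.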

Compound 3, concentration for 50% growth inhibition: 3920 nM
For compound 3 the middle estimate is 1.4-fold (0.15 log units) above the measured one; the measured number falls inside the stated range.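

In this assay, placing 4-(trifluoromethyl)phenyl instead of 2,4-dichlorophenyl on the amide-type nitrogen gives a 1.3-fold higher number from compound 2 to compound 3 (0.11 log units; within the scatter), so this assay cannot tell these two aryl groups apart, even though they differ in their atoms and in where their substituents sit. Among the compounds shown here, the result also gives the first comparison that isolates the nitro group: hydrogen in place of nitro on an aromatic carbon gives an at least 5.1-fold lower number from compound 1 to compound 3 (0.70 log units; beyond the scatter), which shows that the trifluoromethyl group does not by itself push a compound of this series to the top of the tested range. That step can be stated only as a minimum, and its true size stays unknown, because the value for compound 1 is a limit and not a number: the limit of > 20000 nM in this assay, at which 1 of the 3 values shown sits.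

Still open, on these data alone, is how a phenyl ring carrying only a nitro group, or no substituent at all, would behave on this nitrogen, since the nitro group is seen here only together with trifluoromethyl. Also open, as far as these compounds go, is whether an amine or a carboxylic acid on this ring would move the number beyond the scatter in either direction.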